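The source may hold more compounds than are shown below. What is called first, only, known or untested is meant among the compounds shown, and "the series" means these compounds.

Working notes on the series. In an ADME assay on microsomes from liver (Rattus norvegicus) for metabolic stability, read by LC-MS, with a stated time of 30 min, tested at 0.5 uM (a higher number here means that more of the compound is left, a lower number that less of the compound is left), compound 1 `c1ccc(-c2cc(-c3csc(N=C4NCCCN4)n3)cs2)cc1` gives 30% and compound 2 `Oc1ccc(-c2nc(-c3csc(N=C4NCCCN4)n3)cs2)cc1` gives 53%. Compound 2 therefore holds the higher of the two numbers, and its gap to compound 1 lies beyond the usual scatter. These two compounds differ in more than one place, so the gap cannot be tied to any single structural change.

The next compound, compound 3 `c1cc(-c2nc(-c3csc(N=C4NCCCN4)n3)cs2)ccn1`, keeps the core of compound 2 and carries pyridin-4-yl in place of 4-hydroxyphenyl on an aromatic carbon. For the measured compounds named here, no measured pair isolates this exchange, so the expectation for this assay is weakly founded. It rests only on the spread between compound 1 at 30% and compound 2 at 53%. The expected change is a number 8 percentage points lower from compound 2 to compound 3 (within the scatter), a modest fall that is not expected to go beyond the scatter. The range is kept wide, reaching towards the lower measured number and past the higher one. For compound 3 the estimated value is 45%, with an expected range from 22% to 68%.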

Compound 3, percent of the compound remaining: 9%
Beside the measured number, compound 3's estimate is 36 percentage points above it; the measured number lies below the stated range.
By their numbers in this assay, from the lowest: compound 3; then compound 1; then compound 2.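

Putting pyridin-4-yl in place of 4-hydroxyphenyl on an aromatic carbon of the five-membered aromatic ring with 1 nitrogen and 1 sulfur gives a number 44 percentage points lower from compound 2 to compound 3 (beyond the scatter) in this assay. For the compounds shown here, this is the only step that differs in one place, and it shows that the group on this carbon can by itself move the percent of compound remaining by a large margin, which the pair of compound 1 and compound 2 could not show. The exchange keeps a six-membered aromatic ring and the hydrogen-bond acceptor count, yet it replaces a ring carbon with nitrogen and removes the hydrogen-bond donor, and no measurement at hand bears on the reason for the fall.

The step from compound 2 to compound 3 carries the loss of the hydroxyl and the entry of the ring nitrogen together, so the share of each remains unresolved. Open too, from the compounds shown here alone, is how 4-methoxyphenyl, 4-aminophenyl or pyridin-3-yl on the same carbon would read, which would help separate those two parts of the exchange.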